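Methylcarbamoyl Imidazole in Place of a Dimethylcarbamoyl Pyrazole

The compounds below may be only part of what the source reports. "The series", "measured", "known", "first", "only" and "open" are said of these compounds alone.

Measured so far in a physicochemical assay for lipophilicity, using the shake flask method, in phosphate buffer, measured as octanol-water partition, with a stated time of 30 min, at pH 7.4; a lower number here means a more polar compound, a higher number a more lipophilic compound:
compound 1 `CN(C)C(=O)c1cc(-c2cnc(NCc3c(F)ccc4c3CCO4)c3cn[nH]c(=O)c23)n(C)n1` — 2.1
compound 2 `O=C1CCCN1c1cnc(NCc2c(F)ccc3c2CCO3)n2cnnc12` — 1.3
compound 3 `CN(C)Cc1ccc2c(c1)CN(c1cnc(NCc3c(F)ccc4c3CCO4)c3cn[nH]c(=O)c13)C2=O` — 2.2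

Among these three numbers compound 1 stands second highest in this assay; compound 3 lies within the scatter of it, while compound 2 lies clearly lower. Compound 4 `CNC(=O)c1ncc(-c2cnc(NCc3c(F)ccc4c3CCO4)c3cn[nH]c(=O)c23)n1C` has not yet been measured. It differs from compound 1 in one place: 1-methyl-2-(methylcarbamoyl)-1H-imidazol-5-yl in place of 3-(dimethylcarbamoyl)-1-methyl-1H-pyrazol-5-yl on an aromatic carbon. The change is small, trading one methyl of the carbamoyl for an amide hydrogen and shifting the ring nitrogens. For the measured compounds named here, no measured pair shows this step, so its size is not known from the data. A modest downward step, beyond the scatter, is expected in this assay: a number 0.50 log units lower from compound 1 to compound 4 (beyond the scatter). Compound 4 is accordingly estimated at 1.6, with a range of 1.1 to 2.1.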

Compound 4, distribution coefficient: 2.5
Beside the measured number, compound 4's estimate is 0.90 log units below it; measured number above the stated range.
By their numbers in this assay, from the lowest: compound 2; then compounds 1, 3 and 4 (each within the scatter of the next, the first and the last beyond it).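

In this assay, 1-methyl-2-(methylcarbamoyl)-1H-imidazol-5-yl in place of 3-(dimethylcarbamoyl)-1-methyl-1H-pyrazol-5-yl gives a number 0.40 log units higher from compound 1 to compound 4 (beyond the scatter), so this position registers a change of its five-membered ring. The step comes with one hydrogen-bond donor more and one heavy atom fewer, yet the number rises. Nothing at hand accounts for its direction.

The ring and the carbamoyl change together here, so the compounds shown do not separate the two. From the compounds shown here alone, how a carboxylic acid or an amine in place of the methylcarbamoyl would read remains open.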